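Trimming an isopropoxy to ethoxy on a weak Bcl-2 inhibitor

A few compounds are considered here, and "the series" means these few. Any claim that something is new, unique, unknown or untested is made for them only; others in the source may bear on it.

In an assay for inhibition of Apoptosis regulator Bcl-2 (Homo sapiens), read by fluorescence polarization, with a stated time of 2 h (on this read-out higher numbers stand for weaker inhibition and lower numbers for stronger inhibition), compound 3 `Cc1c(C(=O)NCCCN2CCN(C)CC2)c(-c2cccc(N3CCN(c4ccc(NS(=O)(=O)c5cccc(OC(C)C)c5)cc4)CC3)c2)c(-c2ccc(Cl)cc2)n1C` gives 2020 nM, the highest of the three numbers recorded. For comparison, compound 1 `Cc1c(C(=O)O)c(-c2cccc(N3CCN(c4ccc(NS(=O)(=O)c5ccc(N[C@H](CCN6CC(O)C6)CSc6ccccc6)c(S(=O)(=O)C(F)(F)F)c5)cc4)CC3)c2)c(-c2ccc(Cl)cc2)n1C` gives 7.7 nM and compound 2 `Cc1c(C(=O)O)c(-c2cccc(N3CCN(c4ccc(NS(=O)(=O)c5ccc(N[C@H](CCN6CCC(O)CC6)CSc6ccccc6)c(S(=O)(=O)C(F)(F)F)c5)cc4)CC3)c2)c(-c2ccc(Cl)cc2)n1C` gives 10.2 nM, both lying far below compound 3 and beyond the scatter. Compound 4 `CCOc1cccc(S(=O)(=O)Nc2ccc(N3CCN(c4cccc(-c5c(C(=O)NCCCN6CCN(C)CC6)c(C)n(C)c5-c5ccc(Cl)cc5)c4)CC3)cc2)c1` is the same molecule as compound 3 except for a single change: hydrogen in place of methyl on a saturated chain carbon bound to an oxygen on an aromatic ring and a saturated chain carbon. Among the measured compounds shown here, no measured pair shows the effect of such a change here. A step of this size is expected to stay within the scatter, so the estimated shift a 1.0-fold lower number from compound 3 to compound 4 (0.00 log units; within the scatter) is essentially none, and compound 4 is expected to give about 2000 nM, within 900 nM to 4500 nM.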

Compound 4, half-maximal inhibitory concentration: 1620 nM
Compound 4: middle estimate off by 1.2-fold (0.09 log units), on the high side, within the range that was stated.
By their numbers in this assay, from the lowest: compounds 1 and 2 (each within the scatter of the next); then compounds 4 and 3 (each within the scatter of the next).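

In this assay, the change from 3-isopropoxyphenyl to 3-ethoxyphenyl gives a 1.2-fold lower number from compound 3 to compound 4 (0.10 log units; within the scatter), the first step measured at this place. The methyl on this saturated chain carbon can therefore be replaced by hydrogen without a shift that can be told from the scatter, at least on this compound with its weak reading.

As far as these compounds go, whether this place tolerates more than a small trim stays open, since a methoxy, a longer chain or an amine in place of the ethoxy would test it. No supporting evidence bears on this result.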